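A 3-chlorophenyl in place of 4-methoxyphenyl

A few compounds are considered here, and "the series" means these few. Any claim that something is new, unique, unknown or untested is made for them only; others in the source may bear on it.

- compound 1 `COc1ccc(Oc2cccc(CN3CCC(n4cc(C)c(=O)[nH]c4=O)CC3)c2)cc1` gives 28000 nM 
- compound 2 `Cc1cn(C2CCN(Cc3cc(Oc4cc(Cl)cc(Cl)c4)ccn3)CC2)c(=O)[nH]c1=O` gives "not determined" (no result reported) 

Among the compounds with values here, in an ADME assay on MRC5 cells (Homo sapiens) for cytotoxicity, read by fluorescence and resazurin assay, with a stated time of 3 days (a lower number here means a stronger inhibitor, a higher number a weaker inhibitor), the only number belongs to compound 1, at 28000 nM and with nothing to be ranked against, since compound 2 has no result. Compound 3 `Cc1cn(C2CCN(Cc3cccc(Oc4cccc(Cl)c4)c3)CC2)c(=O)[nH]c1=O` has not yet been measured. It differs from compound 1 in one place (3-chlorophenyl in place of 4-methoxyphenyl on an oxygen on an aromatic ring), with 3-chlorophenyl in place of 4-methoxyphenyl on an oxygen on an aromatic ring. Within the data shown here, no step between measured compounds is available to show what such a change does in this assay, so the expectation rests on compound 1 at 28000 nM as the sole anchor. The expected step is a 1.4-fold lower number from compound 1 to compound 3 (0.15 log units; within the scatter) and is estimated to stay within the scatter, leaning slightly toward a lower number. Compound 3 is expected at 20000 nM (estimated range 8000 nM to 50000 nM).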

Compound 3, half-maximal inhibitory concentration: 21000 nM
Estimate against measurement, compound 3: 1.1-fold (0.02 log units) below; measured number inside the range.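

In this assay, within the data shown here, the exchange of 4-methoxyphenyl for 3-chlorophenyl on an oxygen on an aromatic ring gives a 1.3-fold lower number from compound 1 to compound 3 (0.12 log units; within the scatter) and is the first step that can be read at this position. This exchange alters both the substituent and its place on the ring, yet the two compounds cannot be told apart in this read-out, so neither the methoxy nor the chloro version stands out here. Nothing at hand explains this result.

As far as these compounds go, it remains open whether a group of a different kind on this ring, such as a carboxylic acid or a dimethylamino group, would move the number beyond the scatter. The compounds shown also leave open whether the chlorine and the methoxy group each matter on their own, since the two changed together.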